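The compounds below may be only part of what the source reports. "The series", "measured", "known", "first", "only" and "open" are said of these compounds alone.

Measured in an ADME assay for permeability, using PAMPA, at pH 7.4; a higher number here means that the compound crosses the layer faster, a lower number that the compound crosses the layer more slowly:
compound 1 `CCOC(=O)c1c(-c2cccc(-c3ccccc3)c2)[nH]c2cc(OC)ccc2c1=O`: 2900 10^-6 cm/s
compound 2 `CCOC(=O)c1c(-c2cccc(OCC)c2)[nH]c2cc(OC)ccc2c1=O`: 260 10^-6 cm/s
compound 3 `CCCOc1cccc(-c2[nH]c3cc(OC)ccc3c(=O)c2C(=O)OCC)c1`: 340 10^-6 cm/s

Compound 3 belongs to the low pair of this small set and is not separated from its ethoxy partner, with a 1.3-fold higher number from compound 2 to compound 3 (0.12 log units; within the scatter). Among the compounds with values here, the single high number is far away, with an 8.5-fold lower number from compound 1 to compound 3 (0.93 log units; beyond the scatter).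

Next is compound 4 `CCOC(=O)c1c(-c2cccc(Cl)c2)[nH]c2cc(OC)ccc2c1=O`, which carries chloro in place of propoxy on an aromatic carbon, chloro in place of propoxy on an aromatic carbon. Within the data shown here, no measured step brings chloro in, so the evidence is indirect. Exchanging the group at this place moved the number strongly when phenyl left, with an 11-fold lower number from compound 1 to compound 2 (1.05 log units; beyond the scatter) and an 8.5-fold lower number from compound 1 to compound 3 (0.93 log units; beyond the scatter). Going from ethoxy to propoxy did not move it beyond the scatter. Neither propoxy nor chloro contains a ring, so compound 4 is expected to sit with the low pair rather than near compound 1. In this assay the expected step is a 1.2-fold higher number from compound 3 to compound 4 (0.07 log units; within the scatter), so no change beyond the scatter is expected, though with wide uncertainty. For compound 4 the estimate is 400 10^-6 cm/s, with an expected range of 140 10^-6 cm/s to 1200 10^-6 cm/s.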

Compound 4, apparent permeability: 950 10^-6 cm/s
Compound 4: middle estimate off by 2.4-fold (0.38 log units), on the low side, within the range that was stated.
By their numbers in this assay, from the lowest: compounds 2 and 3 (each within the scatter of the next); then compound 4; then compound 1.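

Groups without a ring on this aromatic carbon are not interchangeable in this assay and chloro stands clear of both propoxy (a 2.8-fold higher number from compound 3 to compound 4 (0.45 log units; beyond the scatter)) and ethoxy (a 3.7-fold higher number from compound 2 to compound 4 (0.56 log units; beyond the scatter)). Chloro also remains separate from phenyl (a 3.1-fold lower number from compound 1 to compound 4 (0.48 log units; beyond the scatter)), so the series no longer divides into a low pair and one high compound, and the absence of a ring does not by itself fix the number at the low level. No measurement shown accounts for this order.

Open, from the compounds shown here alone, is whether the number follows chloro itself or simply the fewer heavy atoms of the entering group. Going by these compounds, a bromo, methyl or amine group at this place would bear on that question, and whether the same order holds on a changed version of the shared core also remains open.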